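A Nitro Swap Awaiting Its Growth Inhibition Number

The source may report more compounds than this note shows. Statements on the series, on what has been measured and on what is new or still open speak of the compounds shown alone.

In a functional assay on ACHN cells (Homo sapiens) for inhibition, read by sulforhodamine B assay (on this read-out lower numbers stand for stronger inhibition of growth and higher numbers for weaker inhibition of growth), compound 1 (`O=C(CCC1=CCCN(Cc2ccc(F)cc2)C1=O)NO`) has no single number, only the entry "not determined" (no result reported). For the measured compounds named here, the sole measured reference is compound 2 (`O=C(CCC1=CCCN(CCCCc2ccc(-c3ccccc3)cc2)C1=O)NO`), which gives 2670 nM. Compound 3 (`O=C(CCC1=CCCN(Cc2ccc([N+](=O)[O-])cc2)C1=O)NO`) awaits measurement. The structural change is nitro in place of fluoro on an aromatic carbon, with nitro in place of fluoro on an aromatic carbon, para to a large group. Going by the values given here, no measured step gauges this swap, so no step beyond the usual scatter is expected in this assay, in either direction. For compound 3 the expected value is 5000 nM, with an estimated range from 1500 nM to 20000 nM.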

Compound 3, concentration for 50% growth inhibition: 5210 nM
For compound 3 the middle estimate is 1.0-fold (0.02 log units) below the measured one; measured number inside the range.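

With compound 1 holding no single number in this assay, no step can be read between compound 1 and compound 3. The compounds shown leave open what nitro in place of fluoro does to growth inhibition, and no evidence at hand bears on this result.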